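The source may report more compounds than this note shows. Statements on the series, on what has been measured and on what is new or still open speak of the compounds shown alone.

Measured compounds: compound 1 `COc1ccc(CN2C(=O)C(=O)c3cc(/C=C/C(=O)OC(C)(C)C)ccc32)cc1` gives 310 nM in a functional assay on Jurkat cells (Homo sapiens) for antiproliferative activity, read by MTT assay, with a stated time of 48 h; a higher number here means a weaker inhibitor, a lower number a stronger inhibitor; compound 2 `CC(C)(C)OC(=O)/C=C/c1ccc2c(c1)C(=O)C(=O)N2Cc1ccc(Br)cc1` gives 1040 nM; compound 3 `COC(=O)/C=C/c1ccc2c(c1)/C(=N/O)C(=O)N2Cc1ccc(OC)cc1` gives 9110 nM.

The first two share one core, and the step between them is a single change bromo in place of methoxy on an aromatic carbon that produced a 3.4-fold higher number from compound 1 to compound 2 (0.53 log units; beyond the scatter). Compound 3 has a different core, and the difference between the two cores is not broken down here; its value in this assay stands well above those of compound 1 and compound 2. Compound 4 `COC(=O)/C=C/c1ccc2c(c1)/C(=N/O)C(=O)N2Cc1ccc(Br)cc1` has not yet been measured. It differs from compound 3 by bromo in place of methoxy on an aromatic carbon, the same change already seen between compound 1 and compound 2.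

Within the data shown here, because the one measured step of a 3.4-fold higher number from compound 1 to compound 2 (0.53 log units; beyond the scatter) weakened inhibition, a step of similar size, a 2.7-fold higher number from compound 3 to compound 4 (0.44 log units; beyond the scatter), is expected here, resting on that single precedent. Compound 4 is therefore estimated at 25000 nM, with a likely range from 8000 nM to 70000 nM.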

Compound 4, half-maximal inhibitory concentration: 5860 nM
Estimate against measurement, compound 4: 4.3-fold (0.63 log units) above; the measured number lies below the stated range.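

In this assay, bromo in place of methoxy on the core of compound 3 gave a 1.6-fold lower number from compound 3 to compound 4 (0.19 log units; within the scatter), so the loss seen on the core of compound 1 did not recur. The change therefore cannot be carried from one core to the other in this series as a step of fixed size: the same change on two cores in this assay, a 3.4-fold higher number (0.53 log units; beyond the scatter) from compound 1 to compound 2 and a 1.6-fold lower number (0.19 log units; within the scatter) from compound 3 to compound 4, 5.2-fold (0.72 log units) apart, beyond the scatter of two such steps. Among these compounds, with only two pairs, this shows that the outcome differs between these two cores, but it does not show which feature of the cores accounts for that, or how the change would behave on any third core.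

The compounds shown leave open how an amine or a nitrile in place of the bromo or methoxy would behave on either core. Also open, from the compounds shown here alone, is what a carboxylic acid in place of the ester would do.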